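Amide-Bearing Piperidine Replaces Benzylamine in a Chemokine Receptor Series

The compounds below may be only part of what the source reports. "The series", "measured", "known", "first", "only" and "open" are said of these compounds alone.

Compound 1 `COc1cc2nc(NCc3ccccc3)nc(NC3CCCCCC3)c2cc1OC` carries a benzylamino group beside a cycloheptylamino group on the shared core. In an in vitro functional assay on B300-19 cells for antagonist activity at C-C chemokine receptor type 4 (Homo sapiens), read by GTPgammaS binding, tested at 1 uM (a higher number here means more inhibition at the concentration tested (going by the name of the read-out), a lower number less inhibition), compound 1 gives 13%, the highest of the two numbers in the set. Its nearest neighbour is compound 3 `COc1cc2nc(N3CCC(N4CCCC4)CC3)nc(N3CCCCC3)c2cc1OC`, which in this assay gives 8%, a value within the scatter of compound 1. Compound 2 `COc1cc2nc(N3CCC(N4CCCC4)CC3)nc(N(C)C)c2cc1OC` returns only a limit of the assay in this assay, < 0%, and no number (the limit of < 0% in this assay, at which 1 of the 3 values shown sits).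

For the measured compounds named here, the single traceable step, a number at least 8 percentage points higher from compound 2 to compound 3 (that floor lies within the scatter), concerns a substituent that compound 4 `COc1cc2nc(N3CCC(C(N)=O)CC3)nc(NC3CCCCCC3)c2cc1OC` does not alter, so it bears on the new compound only indirectly. Compound 4 differs from compound 1 in 4-carbamoylpiperidin-1-yl in place of benzylamino on an aromatic carbon. Compounds 1 and 3 differ in two places, and their values in this assay lie within the scatter of each other; compounds 2 and 3, which carry a different piperidinyl group at the same position, both sit low. Going by the values given here, no measured step isolates this change, so no movement beyond the scatter is expected in either direction.

Compound 4 is therefore estimated at 8% in this assay, with a range from -6% to 22%, an expected step of a number 5 percentage points lower from compound 1 to compound 4 (within the scatter).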

Compound 4, a percentage reported as inhibition, at one concentration (the size of the read-out at that concentration, not a potency): 17%
For compound 4 the middle estimate is 9 percentage points below the measured one, and the stated range covers the measured number.
By their numbers in this assay, from the lowest: compounds 3, 1 and 4 (each within the scatter of the next). At a limit, below all of these: compound 2.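

In this assay, exchanging benzylamino for 4-carbamoylpiperidin-1-yl on the aromatic carbon between two ring nitrogen atoms, with the cycloheptylamino group left in place, gives a number 4 percentage points higher from compound 1 to compound 4 (within the scatter). This is the first step shown that isolates a change at this position, and it shows that a six-membered non-aromatic ring carrying a carbamoyl group can replace the benzyl-bearing amine with no movement beyond the scatter, so the aromatic ring of benzylamino is not needed there to keep inhibition at this level. None of the data shown gives a measurement that bears on why the result came out this way.

The compounds shown leave open whether a carboxylic acid, a primary amine or a longer chain in place of the carbamoyl group on the piperidine would move the read-out beyond the scatter in either direction. As far as these compounds go, it also remains open what a 4-(pyrrolidin-1-yl)piperidin-1-yl group would give at this position with the cycloheptylamino group held constant, a comparison that would link compound 4 to compound 3 through single changes.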